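The source may report more compounds than this note shows. Statements on the series, on what has been measured and on what is new or still open speak of the compounds shown alone.

Compound 1 `NC(C/C=C(\c1ccc(-c2ccccc2)cc1)c1ccc(F)cc1F)C(=O)O`: > 10000 nM, a limit of the assay. Compound 2 `CCc1ccc(/C(=C\CC(N)C(=O)O)c2ccc(F)cc2F)cc1`: > 10000 nM, a limit of the assay. Compound 3 `CC(C)c1ccc(/C(=C\CC(N)C(=O)O)c2ccccc2)cc1`: 8340 nM.

In a functional assay for inhibition of sodium- and chloride-dependent glycine transporter 1 (Rattus norvegicus), with a stated time of 30 min, in the presence of a further agent that is not named here (on this read-out lower numbers stand for stronger inhibition and higher numbers for weaker inhibition), compound 2 gives only a limit, > 10000 nM, so it stands among the weak inhibitors without a number of its own. Compound 1 sits at the same limit, (the limit of > 10000 nM in this assay, at which 2 of the 3 values shown sit). Compound 3 gives a number of its own, 8340 nM. Going by the values given here, the one measured step, a step that the two limits leave unreadable from compound 1 to compound 2, is unreadable because both ends are limits. Compound 4 `NC(C/C=C(\c1ccccc1)c1ccc(F)cc1F)C(=O)O` differs from compound 2 by hydrogen in place of ethyl on an aromatic carbon, sitting on an aromatic carbon of a six-membered aromatic ring of carbon only, para to a large group. Among the compounds with values here, no measured pair shows this change, so no step beyond the scatter is expected. Compound 4 is therefore estimated at 12000 nM (range 3000 nM to 40000 nM), an expected step that the limit leaves unreadable from compound 2 to compound 4.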

Compound 4, half-maximal inhibitory concentration: 9500 nM
For compound 4 the middle estimate is 1.3-fold (0.10 log units) above the measured one; the measured number falls inside the stated range.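

In this assay, hydrogen in place of ethyl gives an at least 1.0-fold lower number from compound 2 to compound 4 (0.02 log units; that floor lies within the scatter), and hydrogen in place of phenyl gives an at least 1.0-fold lower number from compound 1 to compound 4 (0.02 log units; that floor lies within the scatter). At this place, para to a large group, the bare ring thus gives compound 4 a number of its own, so neither ethyl nor phenyl is required for a readable value. Both steps start from a limit of the assay, so only their floors can be read: the limit of > 10000 nM in this assay, at which 2 of the 4 values shown sit.

On these data alone, the true size of both steps remains open. So does how an amine or a chlorine atom at this place would compare with compound 4.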